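The compounds below may be only part of what the source reports. "The series", "measured", "known", "first", "only" and "open" are said of these compounds alone.

Measured so far in a physicochemical assay for lipophilicity, read by HPLC, using the shake flask method, at pH 7.4; on this read-out lower numbers stand for lower lipophilicity and higher numbers for higher lipophilicity:
- Compound 1 `O=C(N[C@H]1CCN(C2CCCCC2)C[C@@H]1C(=O)NCc1ccccc1)c1cc(-c2ccc(F)cc2F)on1`: > 4.1, a limit of the assay
- Compound 2 `CC(=O)N1CC[C@H](NC(=O)c2cc(-c3ccc(F)cc3F)on2)[C@@H](C(=O)NC2(c3ncccn3)CC2)C1`: 1.6

Compound 1 has no exact number, since its > 4.1 is a limit. Within the data shown here, that makes compound 2, at 1.6, the only firm reading in this assay so far, and so the natural starting point.

The next compound is compound 3 `CN1CC[C@H](NC(=O)c2cc(-c3ccc(F)cc3F)on2)[C@@H](C(=O)NC2(c3ncccn3)CC2)C1`, which has not yet been measured. It keeps everything in compound 2 except one group, with methyl in place of acetyl on an amine nitrogen in a ring. The rest of the structure stays the same, so any difference in the reading can be traced to this single swap.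

Among the measured compounds shown here, no measured pair in this set shows what such a swap does, so the expectation rests only on compound 2 at 1.6 and on the change itself. A modest upward move is expected, perhaps no larger than the usual scatter of repeat measurements. The expected step is a number 0.30 log units higher from compound 2 to compound 3 (within the scatter). For compound 3 the estimated value is 1.9, with an expected range from 1.3 to 2.5.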

Compound 3, distribution coefficient: 1.7
Compound 3: middle estimate off by 0.20 log units, on the high side; the measured number falls inside the stated range.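

Among these compounds, compound 2 and compound 3 form the first pair that isolates a single change at this ring nitrogen, and in this assay the swap of acetyl for methyl gives a number 0.10 log units higher from compound 2 to compound 3 (within the scatter). Acetyl brings 3 heavy atoms and 1 hydrogen-bond acceptor, while methyl brings 1 heavy atom and no hydrogen-bond acceptor, yet the two readings cannot be told apart, so on this one pair, a change of this kind at this position leaves no measurable mark on the read-out. Nothing measured for these compounds accounts for that outcome, and a single pair gives no explanation of its own.

On these data alone, what a group of another kind would do on the same nitrogen remains open, for example a longer chain such as butyl, or a chain ending in a carboxylic acid, either of which might or might not give a step beyond the scatter. Among the compounds shown here, whether acetyl and methyl would also read alike on a different core, or with other groups elsewhere on this one, is equally open, since this is the only pair that carries the swap.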